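Phenyl replacing pyrrolidinylamino on the indazole series

This account rests on a few compounds, and the source may have more. Where it says the series, first, only, none or still open, it means among the compounds named here.

Measured so far:
Compound 1, `Fc1ccc(-n2cc(-c3n[nH]c4cc(Cl)c(N[C@@H]5CCNC5)cc34)cn2)cc1`, 2300 nM
Compound 2, `Cn1cc(-c2n[nH]c3ccc(N[C@@H]4CCNC4)cc23)cn1`, 37000 nM
Compound 3, `CC(C)Nc1ccc2c(-c3cnn(C)c3)n[nH]c2c1`, 46600 nM

Of the compounds shown here, three have been tested in an assay on isolated protein for inhibition of tyrosine-protein kinase receptor UFO (Homo sapiens), with a stated time of 1.5 h; on this read-out lower numbers stand for stronger inhibition and higher numbers for weaker inhibition. Compound 2 gives 37000 nM, the second highest of the three numbers. Its nearest neighbour is compound 3, which gives 46600 nM, a number within the scatter of compound 2, so no order can be read between the two. Compound 1, with 2300 nM, stands beyond the scatter below compound 2 and gives the lowest number of the set.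

Compound 4, `Cn1cc(-c2n[nH]c3ccc(-c4ccccc4)cc23)cn1`, has not yet been measured. Compared with compound 2 the change is phenyl in place of (pyrrolidin-3-yl)amino on an aromatic carbon. Among the measured compounds shown here, no pair among the measured compounds shows this change, so the size of the step from compound 2 to compound 4 in this assay is not known from the data. Compound 4 is expected to give a number near that of compound 2 or higher, and the step of a 1.6-fold higher number from compound 2 to compound 4 (0.21 log units; within the scatter) is estimated as modest, possibly not beyond the scatter. For compound 4 the estimate in this assay is 60000 nM, with a range from 15000 nM to 200000 nM.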

Compound 4, half-maximal inhibitory concentration: 620 nM
Compound 4: middle estimate off by 97-fold (1.99 log units), on the high side, outside the stated range (below it).
By their numbers in this assay, from the lowest: compound 4; then compound 1; then compounds 2 and 3 (each within the scatter of the next).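

In this assay, phenyl in place of (pyrrolidin-3-yl)amino on an aromatic carbon gives a 60-fold lower number from compound 2 to compound 4 (1.78 log units; beyond the scatter), a large step and the first one that can be read at this position, para to a fused ring. The earlier compounds shown here 1 and 2 both carry (pyrrolidin-3-yl)amino and so could not show whether a low number at this place depends on that group; compound 4 shows that it does not, since a six-membered aromatic ring of carbon only, with 0 hydrogen-bond donors, 0 hydrogen-bond acceptors and no defined stereocentre, gives a far lower number than compound 2 on the same core. Nothing in hand explains the size of this step.

On these data alone, whether the aromatic ring itself matters stays open, as a saturated cyclohexyl ring, a pyridine ring or a phenyl bearing an amine or a carboxylic acid could each settle what this position accepts. As far as these compounds go, it is also open whether the same replacement would produce a step of similar size on the core of compound 1.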